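Cell tolerance of a pyrazolyl compound and a triazolyl analogue

This account rests on a few compounds, and the source may have more. Where it says the series, first, only, none or still open, it means among the compounds named here.

Compound 1, `COc1cnc(-c2cnccn2)c2[nH]cc(C(=O)C(=O)N3CCN(C(=O)c4ccccn4)[C@@H](C)C3)c12`: >= 267000 nM
Compound 2, `COc1cnc(-n2cc(C)cn2)c2[nH]cc(C(=O)C(=O)N3CCN(C(=O)c4ccccc4)CC3)c12`: 243000 nM
Compound 3, `COc1cnc(-n2ccc(CN(C)C)n2)c2[nH]cc(C(=O)C(=O)N3CCN(C(=O)c4ccccc4)[C@H](C)C3)c12`: > 300000 nM

Going by the values given here, in a functional assay on MT2 cells (Homo sapiens) for cytotoxicity, read by XTT assay, with a stated time of 3 days (a lower number here means that less compound is tolerated, a higher number that more compound is tolerated), compound 2 is the only compound of the three that gives a number, 243000 nM. The value of compound 1 is a limit of the assay (the limit of >= 267000 nM in this assay, at which 1 of the 3 values shown sits). The value of compound 3 is likewise a limit (the limit of > 300000 nM in this assay, at which 1 of the 3 values shown sits). Compound 4, `COc1cnc(-n2cnc(C(=O)N(C)C)n2)c2[nH]cc(C(=O)C(=O)N3CCN(C(=O)c4ccccc4)CC3)c12`, has not yet been measured in this assay; it differs from compound 2 by 3-(dimethylcarbamoyl)-1H-1,2,4-triazol-1-yl in place of 4-methyl-1H-pyrazol-1-yl on an aromatic carbon. Among the compounds with values here, no step between measured compounds is available to gauge this change, so in this assay no movement beyond the scatter is expected in either direction. Compound 4 is expected to give 250000 nM, between 120000 nM and 300000 nM. The expected step of a 1.0-fold higher number from compound 2 to compound 4 (0.01 log units; within the scatter) is estimated to stay within the scatter.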

Compound 4, half-maximal cytotoxic concentration: > 300000 nM
Compound 4: no number, only a limit; the forecaster's own chance of this, stated with the estimate: 50%; at least 1.2-fold (0.07 log units) between middle value and limit.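

Compound 4 gives no number, only a limit of the assay: the limit of > 300000 nM in this assay, at which 2 of the 4 values shown sit.

In this assay, placing 3-(dimethylcarbamoyl)-1H-1,2,4-triazol-1-yl on this aromatic carbon, para to a methoxy group, gives an at least 1.2-fold higher number from compound 2 to compound 4 (0.09 log units; that floor lies within the scatter). This first step at the position therefore shows no loss of tolerance with the larger group, although its size remains unresolved.

The compounds shown leave open how far the true value of compound 4 lies beyond its limit. They also leave open whether a carboxylic acid or a longer chain in place of the dimethylcarbamoyl group would shift the reading.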